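Swapping an aromatic ring for isopropyl on the amide nitrogen

The source may report more compounds than this note shows. Statements on the series, on what has been measured and on what is new or still open speak of the compounds shown alone.

Measured so far:
compound 1, `Cc1ccc(OCC(=O)N(Cc2cccs2)c2ccnn2C)cc1`, 422 nM
compound 2, `CCN(Cc1cccs1)C(=O)COc1ccc(OC)cc1`, 120 nM
compound 3, `CCN(Cc1cccs1)C(=O)c1cc2cc(C)ccc2s1`, 1600 nM

In an assay on HEK293 cells for agonist activity at transient receptor potential cation channel subfamily M member 8 (Homo sapiens), read by fluorescence and calcium flux, with a stated time of 15 min (a lower number here means that less compound is needed, a higher number that more compound is needed for the effect), compound 1 gives 422 nM, which places it second highest among the three numbers seen. The nearest value belongs to compound 2, which needs a clearly lower concentration, and the furthest belongs to compound 3, which needs a clearly higher one; both gaps lie beyond the usual scatter of this assay.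

The step under consideration leads from compound 1 to compound 4, `Cc1ccc(OCC(=O)N(Cc2cccs2)C(C)C)cc1`. The change is isopropyl in place of 1-methyl-1H-pyrazol-5-yl on an amide-type nitrogen. Everything else in the molecule is kept.

Among the measured compounds shown here, no directly comparable pair among the measured compounds shows this exact swap, so the expectation rests on indirect hints. Compound 2 also carries a small saturated group, rather than a ring, on its amide-type nitrogen, and in this assay compound 2 gives 120 nM, the lowest number of the three. That suggests a ring on the nitrogen is not required for activity. Compound 4 is therefore expected to sit somewhat below compound 1, with the step of a 1.7-fold lower number from compound 1 to compound 4 (0.23 log units; within the scatter) estimated as modest and possibly within the scatter. The estimate for compound 4 is 250 nM, with a likely range from 80 nM to 800 nM.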

Compound 4, half-maximal effective concentration: 70 nM
Compound 4: middle estimate off by 3.6-fold (0.55 log units), on the high side, outside the stated range (below it).
By their numbers in this assay, from the lowest: compounds 4 and 2 (each within the scatter of the next); then compound 1; then compound 3.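

In this assay, among the compounds shown here, replacing 1-methyl-1H-pyrazol-5-yl with isopropyl on the amide-type nitrogen gives a 6.0-fold lower number from compound 1 to compound 4 (0.78 log units; beyond the scatter) and provides the first direct reading of this position. For the compounds shown here, no earlier pair differed in this one place alone. It shows that, on this core, the five-membered aromatic ring and its two hydrogen-bond acceptors are not needed for the effect, since the smaller isopropyl group, with no ring and no hydrogen-bond acceptors, needs clearly less compound. No measurement shown here explains why the number falls, so the cause remains unknown.

This single swap changes the ring, the two nitrogens and the number of heavy atoms all at once, so the compounds shown cannot say which of these differences matters. A phenyl ring on this nitrogen would keep an aromatic ring without the ring nitrogens and so help separate those factors, while cyclopropyl or tert-butyl would show whether other saturated groups at this place give numbers like that of compound 4.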